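Urea-to-amide change at the carbonyl of the shared core

The source may report more compounds than this note shows. Statements on the series, on what has been measured and on what is new or still open speak of the compounds shown alone.

Measured compounds and their values:
- compound 1, `CNC(=O)c1cc(Oc2ccc3nc(NC(=O)c4ccc(Cl)cc4)sc3c2)ccn1`: 83%
- compound 2, `CNC(=O)c1cc(Oc2ccc3nc(NC(=O)Nc4ccc(Cl)cc4)sc3c2)ccn1`: 77.4%
- compound 3, `CNC(=O)c1cc(Oc2ccc3nc(NC(=O)Nc4ccc(C5CCN(C(C)C)CC5)cc4)sc3c2)ccn1`: 91.6%

In a functional assay on SK-BR-3 cells (Homo sapiens) for inhibition, read by MTT assay, with a stated time of 2 days, tested at 100 uM (on this read-out higher numbers stand for more inhibition of growth at the one concentration tested and lower numbers for less inhibition of growth), compound 2 gives the lowest of the three numbers. Its nearest neighbour is compound 1, and the pair is covered by a number 5.6 percentage points lower from compound 1 to compound 2 (within the scatter), a step that stays within the scatter. Its furthest neighbour is compound 3, reached by a number 14.2 percentage points higher from compound 2 to compound 3 (beyond the scatter), a step beyond the scatter.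

Compound 4, `CNC(=O)c1cc(Oc2ccc3nc(NC(=O)c4cccc(F)n4)sc3c2)ccn1`, has not been measured. The change from compound 2 to compound 4 is 6-fluoropyridin-2-yl in place of (4-chlorophenyl)amino on a carbonyl carbon. Among the measured compounds shown here, of the measured steps, the one from compound 1 to compound 2 bears most directly on it, since that step also swaps what sits on the carbonyl carbon; it was within the scatter. The step from compound 2 to compound 3 alters the group on the aromatic carbon instead and says little about this change. For the measured compounds named here, no measured step introduces a ring with one hetero atom at this position, so that part of the change is untested here.

On this basis no step beyond the scatter is expected for a number 2.6 percentage points higher from compound 2 to compound 4 (within the scatter), and compound 4 is estimated at 80% in this assay, in the range 62% to 94%.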

Compound 4, percent growth inhibition at one concentration: 89.4%
Beside the measured number, compound 4's estimate is 9.4 percentage points below it; measured number inside the range.
By their numbers in this assay, from the lowest: compounds 2, 1, 4 and 3 (each within the scatter of the next, the first and the last beyond it).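

In this assay, among the compounds shown here, 6-fluoropyridin-2-yl in place of (4-chlorophenyl)amino on the carbonyl carbon gives a number 12 percentage points higher from compound 2 to compound 4 (beyond the scatter) and is the only change at this carbonyl so far to pass the scatter, whereas the urea-to-amide step alone did not. Set against the amide that carries 4-chlorophenyl, the same ring gives a number 6.4 percentage points higher from compound 1 to compound 4 (within the scatter) and so cannot be told apart from it, which shows that a six-membered aromatic ring with 1 hetero atom is accepted on this carbonyl carbon without a separable change in growth inhibition. Nothing measured here explains the step from compound 2 to compound 4.

Open, going by these compounds, is whether the fluoro group or the ring hetero atom matters at this position, a question that plain pyridin-2-yl or 6-chloropyridin-2-yl on the same carbonyl would address. Also open, on these data alone, is whether a basic-free ring such as phenyl, or a saturated amine such as piperidin-1-yl, would keep the number in this range, and a single-concentration read-out cannot show how these compounds differ at lower concentrations.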